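The source may report more compounds than this note shows. Statements on the series, on what has been measured and on what is new or still open speak of the compounds shown alone.

Two cores appear here, each carried by a pair of compounds that differ only in the group on the outer ring. Compound 1 `Cc1ccc(-c2cc3cc(C#N)c(C#N)cc3n2O)cc1` carries a methyl there, and in an assay on isolated protein for inhibition of Amine oxidase [flavin-containing] B (Homo sapiens), read by fluorescence and spectrophotometry, with a stated time of 20 min (on this read-out lower numbers stand for stronger inhibition and higher numbers for weaker inhibition), compound 1 gives 821 nM. Compound 2 `COc1ccc(-c2cc3cc(C#N)c(C#N)cc3n2O)cc1` differs from it by methoxy in place of methyl on an aromatic carbon, and in this assay compound 2 gives 1790 nM. That change gave a 2.2-fold higher number from compound 1 to compound 2 (0.34 log units; beyond the scatter). Compound 3 `Cc1ccc(-c2cc3cc(C(=O)O)c(C(=O)O)cc3n2O)cc1` has a different core from compound 1; how the two cores differ is not broken down here. In this assay compound 3 reaches only a limit of the assay, > 100000 nM, which is not a number. Compound 4 `COc1ccc(-c2cc3cc(C(=O)O)c(C(=O)O)cc3n2O)cc1` is not yet measured. For the measured compounds named here, it differs from compound 3 by methoxy in place of methyl on an aromatic carbon, the same change as the one between compound 1 and compound 2, made at the same place on the outer ring. Because that same change gave a 2.2-fold higher number from compound 1 to compound 2 (0.34 log units; beyond the scatter), and because compound 3 already sits at the limit of > 100000 nM in this assay, at which 1 of the 3 values shown sits, compound 4 is expected to remain at or beyond that limit, which would be a step that the limit leaves unreadable from compound 3 to compound 4. The estimate for compound 4 is therefore 220000 nM.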

Compound 4, half-maximal inhibitory concentration: > 100000 nM
Compound 4: a limit, no number; the forecaster's own chance of this, stated with the estimate: 90%; the middle value does not contradict the limit.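

No step from compound 3 to compound 4 can be read, because neither gives a number, only a limit of the assay: the limit of > 100000 nM in this assay, at which 2 of the 4 values shown sit.

The compounds shown leave open whether methoxy in place of methyl changes anything on the core of compound 3, and how strongly, if at all, either compound inhibits in this assay.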